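The source may report more compounds than this note shows. Statements on the series, on what has been measured and on what is new or still open speak of the compounds shown alone.

Measured compounds, growth inhibition in a functional assay on SNB-19 cells (Homo sapiens) for inhibition, read by sulforhodamine B assay, with a stated time of 48 h; on this read-out lower numbers stand for stronger inhibition of growth and higher numbers for weaker inhibition of growth:
- compound 1, `Nc1cc(N)c2nc(-c3ccccc3)c(Sc3ccc(F)cc3)nc2c1`: 41700 nM
- compound 2, `COc1cc(CNc2nc3cc(N)cc(N)c3nc2-c2ccccc2)cc(OC)c1OC`: 20900 nM
- compound 3, `COc1ccc(CNc2nc3cc(N)cc(N)c3nc2-c2ccccc2)cc1OC`: < 100000 nM (a limit)

Compound 3 stands only as a limit in this assay. Its value of < 100000 nM is a limit of the assay and not a number, as noted in the limit of < 100000 nM in this assay, at which 1 of the 3 values shown sits. Compound 2, which carries one more methoxy group, gives 20900 nM in this assay. The step that the limit leaves unreadable from compound 2 to compound 3 is therefore unreadable: the size of the change from two methoxy groups on the benzyl ring to three cannot be taken from the data. Compound 1, with a different linker to the shared core, gives 41700 nM in this assay.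

The next compound, compound 4, `COc1ccc(CNc2nc3cc(N)cc(N)c3nc2-c2ccccc2)cc1`, differs from compound 3 as follows: hydrogen in place of methoxy on an aromatic carbon. Cut one bond further out, the change reads 3,4-dimethoxyphenyl to 4-methoxyphenyl. Going by the values given here, no measured step bears readably on this change; the only step of the same kind ends at a limit. For this assay the expectation for compound 4 is therefore anchored on the readable numbers of compound 2 and compound 1 rather than on compound 3, and the expected step that the limit leaves unreadable from compound 3 to compound 4 is given without a measured precedent. Compound 4 is estimated at 35000 nM, with a range from 10000 nM to 100000 nM.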

Compound 4, concentration for total growth inhibition: < 100000 nM
Compound 4: only a limit was reported; the forecaster's own chance of this, stated with the estimate: 35%; the middle value does not contradict the limit.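

Going by these compounds alone, compound 3 and compound 4 both stand only as limits in this assay, so no step between them can be read: the limit of < 100000 nM in this assay, at which 2 of the 4 values shown sit. The compounds shown leave open how far the change from 3,4-dimethoxyphenyl to 4-methoxyphenyl, or any other loss of a methoxy group from that ring, alters growth inhibition.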